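The source may report more compounds than this note shows. Statements on the series, on what has been measured and on what is new or still open speak of the compounds shown alone.

Three closely related compounds have already been tested in an ADME assay on the whole organism with Oryza sativa as the target, tested at 10 uM; on this read-out higher numbers stand for a weaker effect at the one concentration tested and lower numbers for a stronger effect. Compound 1, `CCCCCCc1ccc(NC(=O)N[C@H](C)c2ccccc2)cc1`, gives 101% in this assay. Compound 2, `CCCCCCc1ccc(NC(=O)N[C@@H](C)c2ccccc2)cc1`, gives 99%. Compound 3, `C[C@H](NC(=O)Nc1ccccc1Cl)c1ccccc1`, gives 106%. All three numbers sit close to one another, and compound 2 stands within the usual scatter of both compound 1 and compound 3. For the measured compounds named here, the only measured step between two compounds that differ in a single place is a number 2 percentage points lower from compound 1 to compound 2 (within the scatter), a change within the scatter; it rests on (the fact that compounds 1 and 2 differ only in the configuration as drawn), so swapping the mirror-image arrangement at the chain carbon makes no difference that can be told apart from repeat measurements.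

Compound 4, `C[C@H](NC(=O)Nc1ccc(Br)cc1)c1ccccc1`, has not been measured yet. Relative to compound 2 the change is bromo in place of hexyl on an aromatic carbon. Going by the values given here, no measured step involves this exchange, so only the overall picture guides the expectation: every measured compound gives a number near the point of no effect at the concentration used, and compound 3, which also lacks a hexyl chain, is no different. Compound 4 is therefore expected to give 101%, between 90% and 112%. The estimated step of a number 2 percentage points higher from compound 2 to compound 4 (within the scatter) is expected to stay within the scatter.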

Compound 4, a percentage reported as activity, at one concentration (the size of the read-out at that concentration, not a potency): 96%
Estimate against measurement, compound 4: 5 percentage points above; the measured number falls inside the stated range.
By their numbers in this assay, from the lowest: compounds 4, 2, 1 and 3 (each within the scatter of the next).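

For the compounds shown here, until now the only single-place comparison concerned configuration at the chain carbon, so the group on the aromatic ring had not been tested. In this assay, putting bromo in place of hexyl on this aromatic carbon gives a number 3 percentage points lower from compound 2 to compound 4 (within the scatter), which means that a chain of 6 carbon atoms can give way to a single bromine atom with no difference that can be told apart from repeat measurements. Nothing available here explains this outcome, and it is equally unclear whether either group has any influence of its own on the read-out.

Since compound 2 and compound 4 both give numbers near the point of no effect, this one pair cannot show whether the read-out responds to any change at this position, or whether this whole family of compounds stays near that point at the concentration used. Going by these compounds, it remains open whether a clearly different group here, such as an amine, a carboxylic acid or a chain longer than hexyl, would move the number beyond the scatter.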